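Swapping the aryl group on a pyrazole carboxylic acid core

A few compounds are considered here, and "the series" means these few. Any claim that something is new, unique, unknown or untested is made for them only; others in the source may bear on it.

Measured compounds:
Compound 1 `COc1ccccc1-c1c(C)nn(-c2nc(-c3ccc(Cl)c(Cl)c3)c(SC(C)C)s2)c1C(=O)O` gives 14700 nM in a functional assay on BJAB cells (Homo sapiens) for antiproliferative activity, with a stated time of 4 days; a higher number here means that more compound is needed for the effect, a lower number that less compound is needed.
Compound 2 `Cc1nn(-c2nc(-c3ccc(Cl)c(Cl)c3)c(SC(C)C)s2)c(C(=O)O)c1-c1cc(C#N)cc(C(F)(F)F)c1` gives 3600 nM in this assay.
Compound 3 `Cc1nn(-c2nc(-c3ccc(Cl)c(Cl)c3)c(SC(C)C)s2)c(C(=O)O)c1-c1cccc(F)c1` gives 900 nM in this assay.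

Compound 3 has the lowest number of the three, so it needs the least compound for the effect. The step from compound 1 to compound 3 is large, a 16-fold lower number from compound 1 to compound 3 (1.21 log units; beyond the scatter), and the step from compound 2 to compound 3 is modest, a 4.0-fold lower number from compound 2 to compound 3 (0.60 log units; beyond the scatter); both lie beyond the scatter.

Compound 4 `Cc1nn(-c2nc(-c3ccc(Cl)c(Cl)c3)c(SC(C)C)s2)c(C(=O)O)c1-c1ccccc1[N+](=O)[O-]` differs from compound 3 in the aryl group: 2-nitrophenyl in place of 3-fluorophenyl on an aromatic carbon. For the measured compounds named here, no measured step covers a nitro group. The nearest guide is compound 1, whose 2-methoxyphenyl resembles the 2-nitrophenyl in name, and compound 1 gave the highest number of the three, with a 16-fold lower number from compound 1 to compound 3 (1.21 log units; beyond the scatter) on changing to the 3-fluorophenyl. Because of a 16-fold lower number from compound 1 to compound 3 (1.21 log units; beyond the scatter), the expected step is a higher number, a 5.6-fold higher number from compound 3 to compound 4 (0.74 log units; beyond the scatter), with wide uncertainty. The estimate for compound 4 is 5000 nM, expected to fall between 1500 nM and 16000 nM.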

Compound 4, half-maximal effective concentration: 4700 nM
Compound 4: middle estimate off by 1.1-fold (0.03 log units), on the high side, and the stated range covers the measured number.
By their numbers in this assay, from the lowest: compound 3; then compounds 2 and 4 (each within the scatter of the next); then compound 1.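

Keeping the substituent on the same named ring carbon while changing it from methoxy to nitro shifts the number in this assay (a 3.1-fold lower number from compound 1 to compound 4 (0.50 log units; beyond the scatter)), so the identity of this group matters, not only where it sits on the aryl ring. The 2-nitrophenyl does not match the 3-fluorophenyl (a 5.2-fold higher number from compound 3 to compound 4 (0.72 log units; beyond the scatter)), but it cannot be separated from the larger 3-cyano-5-(trifluoromethyl)phenyl (a 1.3-fold higher number from compound 2 to compound 4 (0.12 log units; within the scatter)), so the two substituted rings sit level here despite their different groups. Nothing measured here explains these differences.

Still open, as far as these compounds go, is how a plain phenyl ring, with no substituent, would compare with all four aryl groups. Also open, from the compounds shown here alone, is whether an amine or a hydroxyl group on the aryl ring would follow the nitro compound or the fluoro compound.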